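The compounds below may be only part of what the source reports. "The series", "measured", "known", "first", "only" and "open" are said of these compounds alone.

Two chalcone-type compounds sharing one core have been measured in a functional assay on ZR-75-1 cells (Homo sapiens) for cytotoxicity, read by MTT assay, with a stated time of 68 h; a lower number here means a stronger inhibitor, a higher number a weaker inhibitor. Compound 1, `O=C(/C=C/c1cccc(OCc2ccccc2)c1)c1ccc([N+](=O)[O-])cc1`, carries a nitro group and gives 37700 nM. Compound 2, `O=C(/C=C/c1cccc(OCc2ccccc2)c1)c1ccc(O)cc1`, carries a hydroxy group instead and gives 4900 nM. Among the measured compounds shown here, the only measured step shows a 7.7-fold lower number from compound 1 to compound 2 (0.89 log units; beyond the scatter), so compound 2 has the lowest of the two numbers, with compound 1 the nearest.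

Compound 3, `O=C(/C=C/c1cccc(OCc2ccccc2)c1)c1ccccc1`, is the unsubstituted counterpart: hydrogen in place of hydroxy on an aromatic carbon. For the measured compounds named here, the one measured step bears on it only indirectly, since it swaps one substituent for another rather than removing one. A plain hydrogen in place of hydroxy might cost some of the gain seen for compound 2, but the evidence is thin, so a small rise in the number, of a size near the scatter, is expected as a 2.0-fold higher number from compound 2 to compound 3 (0.31 log units; beyond the scatter). Compound 3 is therefore estimated at 10000 nM, within 3500 nM to 30000 nM, in this assay.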

Compound 3, half-maximal inhibitory concentration: 8500 nM
For compound 3 the middle estimate is 1.2-fold (0.07 log units) above the measured one; low and high end bracket the measured number.
By their numbers in this assay, from the lowest: compounds 2 and 3 (each within the scatter of the next); then compound 1.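

Taking the hydroxy group away gives a 1.7-fold higher number from compound 2 to compound 3 (0.24 log units; within the scatter) in this assay, so at this place on the ring, para to a large group, hydroxy and plain hydrogen cannot be told apart. Hydrogen in place of nitro gives a 4.4-fold lower number from compound 1 to compound 3 (0.65 log units; beyond the scatter), which changes how the earlier step reads: it looks less like a gain from hydroxy and more like a loss that comes with nitro. Nothing available explains why nitro stands apart from the other two groups.

The compounds shown leave open whether any group at this place can give a clearly lower number than hydrogen, as an amine, a methoxy group or a fluorine atom might. They also leave open whether the higher number is particular to nitro, which a comparison with a nitrile or a carboxylic acid could help to show.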